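The compounds below may be only part of what the source reports. "The series", "measured", "known", "first", "only" and "open" are said of these compounds alone.

Compound 1 `CC(=O)Nc1nc(-c2cccc(NS(=O)(=O)c3ccc(Br)cc3)c2)cs1`: 25.6%
Compound 2 `CC(=O)Nc1nc(-c2cccc(NS(=O)(=O)c3ccc(C#CC4CCCCC4)cc3)c2)cs1`: 1.2%
Compound 3 `C#Cc1ccc(S(=O)(=O)Nc2cccc(-c3csc(NC(C)=O)n3)c2)cc1`: 1.2%

In a functional assay on A-375 cells (Homo sapiens) for antiproliferative activity, read by trypan blue exclusion, with a stated time of 48 h, tested at 10 uM (a lower number here means a stronger effect, a higher number a weaker effect of the compound at the concentration tested), compound 1 gives 25.6%, compound 2 gives 1.2%, and compound 3 gives 1.2%. Compound 3 thus stands level with compound 2, the two of them together at the lowest numbers of the three; its distance from compound 1 is the step of a number 24.4 percentage points lower from compound 1 to compound 3 (beyond the scatter). Compound 4 `CCCCCCCCc1ccc(S(=O)(=O)Nc2cccc(-c3csc(NC(C)=O)n3)c2)cc1` has not yet been measured. It differs from compound 3 in one place: octyl in place of ethynyl on an aromatic carbon.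

Within the data shown here, two measured steps bear on this. The steps of a number 24.4 percentage points lower from compound 1 to compound 2 (beyond the scatter) and a number 24.4 percentage points lower from compound 1 to compound 3 (beyond the scatter) show that replacing bromo with either of the two alkyne groups lowered the number by the same amount. The step of no change at the digits printed from compound 2 to compound 3 (within the scatter) shows that a large cyclohexyl on the triple-bonded carbon, against a bare hydrogen there, made no difference. Among the measured compounds shown here, no measured step swaps a triple bond for a saturated chain, so the carry-over to octyl rests on the observation that the group beyond the aromatic carbon could be changed freely. The expectation is therefore a step of about a number 4.8 percentage points higher from compound 3 to compound 4 (within the scatter), that is, none beyond the scatter. Compound 4 is estimated at 6%, with a range from 0% to 22%.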

Compound 4, a percentage reported as activity, at one concentration (the size of the read-out at that concentration, not a potency): < 1%
Compound 4: a limit, no number; the forecaster's own chance of this, stated with the estimate: 0%; middle value at least 5 percentage points away from the limit.
By their numbers in this assay, from the lowest: compounds 2 and 3 (each within the scatter of the next); then compound 1. At a limit, below all of these: compound 4.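

In this assay, compound 4 carries a limit of the assay and not a number: the limit of < 1% in this assay, at which 1 of the 4 values shown sits.

The steps of a number at least 0.2 percentage points lower from compound 3 to compound 4 (that floor lies within the scatter) and a number at least 0.2 percentage points lower from compound 2 to compound 4 (that floor lies within the scatter) show that a saturated octyl chain, with no triple bond, cannot be told apart from either alkyne group at this position, so a triple bond is not needed here for a reading this low. The step of a number at least 24.6 percentage points lower from compound 1 to compound 4 (beyond the scatter) puts octyl on the same side of the bromo compound as the two alkynes, which leaves compound 1 as the only one of the four set apart.

Compounds 2, 3 and 4 all sit close to the bottom of this read-out at a single concentration, so any difference in potency among them stays hidden, and only tests at lower concentrations could separate them. From the compounds shown here alone, it also remains open whether a carbon chain is required at all on this aromatic carbon, or whether a shorter chain such as methyl, an amine or a carboxylic acid in the same place would give a reading as low or one closer to that of compound 1.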